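Aminohexyl Chain in Place of Phenylethyl on Compound 3

This account rests on a few compounds, and the source may have more. Where it says the series, first, only, none or still open, it means among the compounds named here.

Compound 1 `N[C@H]1CC[C@H](Nc2c(C(=O)NCc3ccc(F)cc3)nc(N3CCCCC3)c3cccnc23)CC1`: 8500 nM
Compound 2 `C[C@@H](CO)Nc1nc(C(=O)NCc2ccc(F)cc2)c(O)c2ncccc12`: "not determined" (no result reported)
Compound 3 `C[C@@H](Nc1c(C(=O)NCc2ccc(F)cc2)nc(Br)c2cccnc12)c1ccccc1`: > 20000 nM

In a functional assay on HCT-116 cells (Homo sapiens) for cytotoxicity, read by MTT assay, with a stated time of 72 h (on this read-out higher numbers stand for weaker inhibition and lower numbers for stronger inhibition), compound 3 reaches only the limit of the assay and gives no number; this is the limit of > 20000 nM in this assay, at which 1 of the 3 values shown sits. Compound 2 has no result at all, so compound 1 alone of the three carries a single measured value in this assay. The change that leads to compound 4 `NCCCCCCNc1c(C(=O)NCc2ccc(F)cc2)nc(Br)c2cccnc12` is 6-aminohexyl in place of 1-phenylethyl on a nitrogen on an aromatic ring. For the measured compounds named here, no step between two measured compounds is available, so the size of this change has no direct precedent here. Compound 4 is expected to come in at 10000 nM, with a range from 3000 nM to 30000 nM. The step of an at least 2.0-fold lower number from compound 3 to compound 4 (0.30 log units; that floor lies within the scatter) is expected to be a gain that goes beyond the usual scatter.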

Compound 4, half-maximal inhibitory concentration: > 10000 nM
Compound 4 was reported as a limit (the forecaster's own chance of this, stated with the estimate: 40%); the middle value lies on the limit itself.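

Compound 3 and compound 4 both stand at limits in this assay, and the step between them cannot be read. As far as these compounds go, whether 6-aminohexyl in place of 1-phenylethyl changes the result in this assay at all remains open.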